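Chloro on the Benzyl Ring: a Repeated Substitution

The compounds below may be only part of what the source reports. "The series", "measured", "known", "first", "only" and "open" are said of these compounds alone.

Measured compounds:
Compound 1, `Cc1cc(S(=O)(=O)/N=C(\N)n2nccc2-c2ccccc2)c(SCc2cccc(Cl)c2)cc1Cl`, gives 88000 nM in a functional assay on MCF7 cells (Homo sapiens) for cytotoxicity, read by MTT assay, with a stated time of 72 h; on this read-out higher numbers stand for weaker inhibition and lower numbers for stronger inhibition.
Compound 2, `Cc1cc(S(=O)(=O)/N=C(\N)n2nccc2-c2ccccc2)c(SCc2ccccc2)cc1Cl`, gives 20000 nM in this assay.
Compound 3, `Cc1cc(-c2ccccc2)n(/C(N)=N/S(=O)(=O)c2cc(C)c(Cl)cc2SCc2ccccc2)n1`, gives 15000 nM in this assay.

Compound 4, `Cc1cc(-c2ccccc2)n(/C(N)=N/S(=O)(=O)c2cc(C)c(Cl)cc2SCc2cccc(Cl)c2)n1`, has not yet been measured in this assay.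

The three measured compounds share a core, and the pair compound 2 and compound 3 differ only in methyl in place of hydrogen on an aromatic carbon. That difference gives a 1.3-fold lower number from compound 2 to compound 3 (0.12 log units; within the scatter), so the two cores behave alike within the scatter of the measurement.

The change from compound 2 to compound 1 is chloro in place of hydrogen on an aromatic carbon. It produced a 4.4-fold higher number from compound 2 to compound 1 (0.64 log units; beyond the scatter), a step toward weaker inhibition that is larger than the usual scatter.

Compound 4 relates to compound 3 exactly as compound 1 relates to compound 2: the change is chloro in place of hydrogen on an aromatic carbon. The place description is the same word for word in both pairs, so this is the same change set on the other core. For the measured compounds named here, only one measured instance of this change exists, so the comparison rests on a single step.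

Because a 4.4-fold higher number from compound 2 to compound 1 (0.64 log units; beyond the scatter) was observed on the closely related core, a step of similar size and direction is expected here, that is a 4.3-fold higher number from compound 3 to compound 4 (0.64 log units; beyond the scatter). Compound 4 is therefore estimated at 65000 nM, with a likely range of 30000 nM to 140000 nM.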

Compound 4, half-maximal inhibitory concentration: 25000 nM
Compound 4: middle estimate off by 2.6-fold (0.41 log units), on the high side, outside the stated range (below it).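

Placing chloro on the benzyl ring of the second core gives a 1.7-fold higher number from compound 3 to compound 4 (0.22 log units; within the scatter) in this assay, a step that stays within the usual scatter, yet it cannot be told apart from the earlier step on the first core: the same change on two cores in this assay, a 4.4-fold higher number (0.64 log units; beyond the scatter) from compound 2 to compound 1 and a 1.7-fold higher number (0.22 log units; within the scatter) from compound 3 to compound 4, 2.6-fold (0.42 log units) apart, within the scatter of two such steps

The methyl change tells the same story from the other side, since it gives a 3.5-fold lower number from compound 1 to compound 4 (0.55 log units; beyond the scatter), which lies beyond the scatter, while its earlier counterpart did not, and still the two steps cannot be separated: the same change on two cores in this assay, a 1.3-fold lower number (0.12 log units; within the scatter) from compound 2 to compound 3 and a 3.5-fold lower number (0.55 log units; beyond the scatter) from compound 1 to compound 4, 2.6-fold (0.42 log units) apart, within the scatter of two such steps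

So these compounds give no sign that the chloro change behaves differently on the two cores, but they do not show that it behaves the same, since each core offers only one pair and a real difference of this size could hide in the scatter of two such steps.

From the compounds shown here alone, it remains open whether a fluoro group, a methoxy group or a carboxylic acid in place of the same hydrogen would follow the chloro step on either core. Going by these compounds, it is also open whether a longer chain such as ethyl in place of the added methyl would match the methyl step.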